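Oxime ester series: removing the acyl group

A few compounds are considered here, and "the series" means these few. Any claim that something is new, unique, unknown or untested is made for them only; others in the source may bear on it.

Compound 1 `COc1ccc(C(=O)ON=C2CC(c3ccc(O)c(OC)c3)N(C)C(c3ccc(O)c(OC)c3)C2)c(OC)c1`: 41000 nM
Compound 2 `COc1cc(C2CC(=NOC(=O)c3ccc(O)cc3)CC(c3ccc(O)c(OC)c3)N2C)ccc1O`: 15100 nM

In a functional assay, read by spectrophotometry, with a stated time of 30 min (a higher number here means a weaker inhibitor, a lower number a stronger inhibitor), compound 1 gives 41000 nM and compound 2 gives 15100 nM. Among the measured compounds shown here, compound 2 therefore stands at the lower of the two numbers so far, with compound 1 as its only neighbour. For the measured compounds named here, the single measured step, a 2.7-fold lower number from compound 1 to compound 2 (0.43 log units; beyond the scatter), accompanies a smaller, hydroxylated aryl group on the carbonyl carbon.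

Compound 3 `COc1cc(C2CC(=NO)CC(c3ccc(O)c(OC)c3)N2C)ccc1O` differs from compound 2 by hydrogen in place of (4-hydroxyphenyl)carbonyl on an oxygen, so the ester is cut away and the free oxime remains. The measured step bears on this only loosely: it altered the aryl part of the acyl group, whereas here the whole acyl group leaves. Going by the values given here, no measured pair removes the acyl group outright, so the direction is open. On the evidence that trimming the acyl group lowered the number, a modest change is expected, a 1.5-fold lower number from compound 2 to compound 3 (0.18 log units; within the scatter), with wide uncertainty. Compound 3 is estimated at 10000 nM, within 3000 nM to 40000 nM.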

Compound 3, half-maximal inhibitory concentration: 158000 nM
Compound 3: the middle estimate sits 16-fold (1.20 log units) below what was measured; the measured number lies above the stated range.
By their numbers in this assay, from the lowest: compound 2; then compound 1; then compound 3.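

In this assay the acyl group on this oxygen turns out to matter in itself, and the loss of (4-hydroxyphenyl)carbonyl gives a 10-fold higher number from compound 2 to compound 3 (1.02 log units; beyond the scatter) as the free oxime remains. Taking away (2,4-dimethoxyphenyl)carbonyl points the same way, with a 3.9-fold higher number from compound 1 to compound 3 (0.59 log units; beyond the scatter) so that, of the three compounds, both aryl esters carry lower numbers than the free oxime, a direction the change between the two esters alone could not give. Nothing at hand accounts for this difference.

Still open, going by these compounds, is whether the carbonyl or the aryl ring carries the lower numbers of the esters. An acetyl group on the same oxygen, which keeps the carbonyl without the aryl ring, and a benzyl group, which keeps the aryl ring without the carbonyl, would separate the two.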